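Thiadiazole-linked anilide series: halogenated aryl in place of dihydroxyphenyl

A few compounds are considered here, and "the series" means these few. Any claim that something is new, unique, unknown or untested is made for them only; others in the source may bear on it.

Measured so far:
compound 1 `Cn1c(Cc2nn(C)c(=O)c3ccccc23)nnc1SCCCCCCCCCCCCCCCC(=O)Nc1ccc(Cl)cc1Cl`: 7300 nM
compound 2 `Cn1c(Cc2nn(C)c(=O)c3ccccc23)nnc1SCCCCCCCC(=O)Nc1ccc(O)cc1O`: 17000 nM
compound 3 `Cn1c(Cc2nn(C)c(=O)c3ccccc23)nnc1SCC(=O)Nc1ccc(F)cc1F`: "not active" (no number reported)

All three share the same core and differ in the chain length between the sulfur and the amide and in the aryl on the amide nitrogen. In an assay on isolated protein (Mus musculus) for inhibition of IL15-IL15 receptor (Homo sapiens), read by resazurin assay, with stated times of 30 min and 2.5 days (on this read-out lower numbers stand for stronger inhibition and higher numbers for weaker inhibition), compound 2 gives 17000 nM, the highest of the two numbers reported; its nearest neighbour, compound 1, gives the lower number, a gap that lies beyond the scatter. Compound 3 is recorded as inactive without a number. Within the data shown here, compound 1 and compound 2 differ in more than one place, so no single-point step is available among the measured compounds.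

Compound 4 `Cn1c(Cc2nn(C)c(=O)c3ccccc23)nnc1SCCCCCCCC(=O)Nc1ccc(Br)cc1Br` has not yet been measured. It differs from compound 2 by one change: 2,4-dibromophenyl in place of 2,4-dihydroxyphenyl on an amide-type nitrogen. Among the measured compounds shown here, no measured pair isolates this exchange. For the measured compounds named here, the only comparison to hand, compound 1 against compound 2 in this assay, points toward a lower number when hydroxyl groups are absent, but with the chain also changed, the weight of that comparison is limited. A modest step downward is expected, a 1.9-fold lower number from compound 2 to compound 4 (0.28 log units; within the scatter), of a size not far beyond the scatter. For compound 4 the expected value in this assay is 9000 nM, with a range from 3000 nM to 30000 nM.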

Compound 4, half-maximal inhibitory concentration: 1500 nM
Compound 4: the middle estimate sits 6.0-fold (0.78 log units) above what was measured; measured number outside the range, below it.
By their numbers in this assay, from the lowest: compound 4; then compound 1; then compound 2.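

In this assay, placing 2,4-dibromophenyl in place of 2,4-dihydroxyphenyl on the amide-type nitrogen gives an 11-fold lower number from compound 2 to compound 4 (1.05 log units; beyond the scatter), with the chain and the shared core unchanged. Among these compounds, this is the only single-change step, and it shows that the aryl group alone can move this read-out well beyond the scatter, which the earlier compounds could not show, as each differs from the others in both chain and aryl. The heavy-atom count stays the same across the exchange, while the 2 hydrogen-bond donors and 2 hydrogen-bond acceptors of the leaving group are replaced by none; no supporting data bear on what accounts for the size of this step.

Still open, on these data alone, is whether the step depends on the two bromine atoms or on the loss of the two hydroxyl groups, a question that an unsubstituted phenyl or a dimethoxyphenyl on this same chain would address. Also open, as far as these compounds go, is how the chain length acts on its own, for example how a longer chain carrying the same 2,4-dibromophenyl would read.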